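The source may report more compounds than this note shows. Statements on the series, on what has been measured and on what is new or still open speak of the compounds shown alone.

Measured compounds and their values:

compound 1, `Cc1cccc(-c2c([C@H](C)Nc3nc(N)nc(N)c3C#N)cc3ccc(F)cn3c2=O)c1`: < 1%
compound 2, `Cc1cc(F)cc(-c2c([C@H](C)Nc3nc(N)nc(N)c3C#N)cc3ccc(F)cn3c2=O)c1`: < 1%
compound 3, `C[C@H](Nc1ncnc(N)c1C#N)c1cc(=O)n2cc(F)ccc2c1-c1ccccc1`: 69%

The read-out throughout is an ADME assay on microsomes from liver (Mus musculus), read by LC-MS, using NADPH, with a stated time of 30 min, tested at 1 uM; a higher number here means that more of the compound is left, a lower number that less of the compound is left. Compound 1 gives < 1%, which is a limit of the assay rather than a number. Compound 2 likewise gives < 1%, again a limit. The change between them is fluoro in place of hydrogen on an aromatic carbon, and the step that the two limits leave unreadable from compound 1 to compound 2 cannot be sized because both values sit at the limit of < 1% in this assay, at which 2 of the 3 values shown sit. The core of compound 3 differs from that of compound 1 in a way that is not broken down here. For the measured compounds named here, compound 3 gives 69%, the only plain number among the three.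

Compound 4, `C[C@H](Nc1ncnc(N)c1C#N)c1cc(=O)n2cc(F)ccc2c1-c1cccc(F)c1`, is not yet measured. Its relation to compound 3 is fluoro in place of hydrogen on an aromatic carbon. Going by the values given here, this is the same kind of change as the one from compound 1 to compound 2, though there the fluoro also sits meta to a methyl group, which is absent here. Since the earlier step is unreadable, no size is carried over from it, and the change from compound 3 to compound 4 is expected to be a number 9 percentage points lower from compound 3 to compound 4 (within the scatter). Compound 4 is therefore estimated at 60%, with a range from 35% to 85%.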

Compound 4, percent of the compound remaining: 83%
The estimate for compound 4 lay 23 percentage points below the measured number; low and high end bracket the measured number.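

In this assay, fluoro in place of hydrogen on an aromatic carbon, here phenyl to 3-fluorophenyl, gives a number 14 percentage points higher from compound 3 to compound 4 (beyond the scatter). The same kind of change on the core of compound 1 cannot be read, because compound 1 and compound 2 both stand at a limit of the assay and not at a number: the limit of < 1% in this assay, at which 2 of the 4 values shown sit. The step is therefore sized on one core only, and it does not show whether the change carries from one core to another, in size or in direction, the more so as the ring in compound 2 also bears a methyl group.

The compounds shown leave open whether the gain on the core of compound 3 is particular to fluoro or would also appear with another group at that place, such as chloro, methoxy or an amine. They also leave open how the change behaves on any further core whose values lie clear of the limit.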